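The compounds below may be only part of what the source reports. "The series", "measured", "known", "first", "only" and "open" are said of these compounds alone.

For the measured compounds named here, in an ADME assay on THP-1 cells (Homo sapiens) for cytotoxicity, read by MTT assay, with a stated time of 72 h (a lower number here means a stronger inhibitor, a higher number a weaker inhibitor), compound 1 (`COc1ccc(/C=C/C(=O)c2c(O)c3ccccc3n(Cc3ccccc3)c2=O)cc1OC`) gives 28700 nM, the only exact number in this small set. For compound 2 (`COc1ccc(/C=C/C(=O)c2c(O)c3ccccc3[nH]c2=O)cc1`), the reading is only a limit, > 50000 nM. Compound 3 (`COc1ccc(/C=C/C(=O)c2c(O)c3ccccc3[nH]c2=O)cc1OC`) differs from compound 2 in one place: methoxy in place of hydrogen on an aromatic carbon, with methoxy in place of hydrogen on an aromatic carbon, ortho to a methoxy group. Going by the values given here, no measured pair isolates this change, so its size can only be estimated. A small effect is expected, most likely none beyond the usual scatter, and the expected change is an at least 1.1-fold lower number from compound 2 to compound 3 (0.04 log units; that floor lies within the scatter). With compound 1 at 28700 nM as the sole numeric reference, the expectation stays near the top of the measurable range. Another limit would be no surprise. Compound 3 is estimated at 45000 nM, with an expected range of 20000 nM to 90000 nM.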

Compound 3, half-maximal inhibitory concentration: > 50000 nM
Compound 3 gave a limit, no number (the forecaster's own chance of this, stated with the estimate: 55%); middle value at least 1.1-fold (0.04 log units) away from the limit.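

In this assay the methoxy change cannot be sized: compound 2 and compound 3 both stand at a limit of the assay, and the step between them cannot be read. For the compounds shown here, compound 3 does supply the first comparison that isolates the aromatic nitrogen, where hydrogen in place of benzyl gives an at least 1.7-fold higher number from compound 1 to compound 3 (0.24 log units; that floor lies within the scatter). That step is only a floor, and the assay's ceiling holds back any firmer reading of it: the limit of > 50000 nM in this assay, at which 2 of the 3 values shown sit.

On these data alone, how far an ethyl group, a longer chain or an amine on the aromatic nitrogen would move the number remains open. Also open, as far as these compounds go, is whether the methoxy change would have a readable size with benzyl on that nitrogen, where compound 1 gives a number rather than a limit.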